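Thiophene to furan swap at the cyano-flanked position

This account rests on a few compounds, and the source may have more. Where it says the series, first, only, none or still open, it means among the compounds named here.

Measured compounds in a functional assay for inhibition, tested at 80 ug/mL; on this read-out higher numbers stand for a stronger effect at the one concentration tested and lower numbers for a weaker effect:
- compound 1 `COc1cc(-c2cc(-c3cc(C(C)C)c(O)cc3C)[nH]c(=O)c2C#N)cc(OC)c1OC` gives 82%
- compound 2 `Cc1cc(O)c(C(C)C)cc1-c1cc(-c2cccs2)c(C#N)c(=O)[nH]1` gives 63%
- compound 3 `COc1ccc(-c2cc(-c3cc(C(C)C)c(O)cc3C)[nH]c(=O)c2C#N)c(OC)c1` gives 55%

Compound 2 stands second highest of the three. Its nearest neighbour is compound 3, reached by the step of a number 8 percentage points lower from compound 2 to compound 3 (within the scatter), which lies within the scatter. Compound 1 sits beyond the scatter above compound 2.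

Compound 4 `Cc1cc(O)c(C(C)C)cc1-c1cc(-c2ccco2)c(C#N)c(=O)[nH]1` is not yet measured. It differs from compound 2 in one place: furan-2-yl in place of thiophen-2-yl on an aromatic carbon.

Within the data shown here, the only measured step at the same place is the one from compound 2 to compound 3, which exchanged the five-membered ring for a substituted six-membered one and stayed within the scatter. Among the measured compounds shown here, no measured pair exchanges thiophen-2-yl for furan-2-yl, so the direction of this smaller change is not fixed by the data. Given that the larger exchange at this position moved nothing beyond the scatter, no step beyond the scatter is expected for compound 4 either: the expected step is a number 3 percentage points lower from compound 2 to compound 4 (within the scatter). Compound 4 is therefore estimated at 60%, expected to fall between 45% and 75%.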

Compound 4, a percentage reported as inhibition, at one concentration (the size of the read-out at that concentration, not a potency): 64%
Compound 4: the middle estimate sits 4 percentage points below what was measured; the measured number falls inside the stated range.
By their numbers in this assay, from the lowest: compounds 3, 2 and 4 (each within the scatter of the next); then compound 1.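

In this assay, furan-2-yl in place of thiophen-2-yl on this aromatic carbon, ortho to a cyano group and opposite the ring nitrogen, gives a number 1 percentage points higher from compound 2 to compound 4 (within the scatter), so this read-out does not separate the two five-membered rings. Furan-2-yl in place of 2,4-dimethoxyphenyl gives a number 9 percentage points higher from compound 3 to compound 4 (within the scatter), which adds a second step at this position that stays within the scatter, now with the oxygen-containing ring as well. No supporting evidence is available to explain why these groups read alike.

Left open is whether an amine, a carboxylic acid or a longer alkyl chain on this aromatic carbon would move the number beyond the scatter. The single tested concentration also leaves open whether these level readings would hold as potencies.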